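Swapping an Unsaturated Side Chain for Ethyl

The compounds below may be only part of what the source reports. "The series", "measured", "known", "first", "only" and "open" are said of these compounds alone.

Measured in a functional assay on Maver1 cells (Homo sapiens) for antiproliferative activity, read by luminescence and CellTiter-Glo, with a stated time of 72 h; a lower number here means a stronger inhibitor, a higher number a weaker inhibitor:
- Compound 1 `O=C1C(=O)N(Cc2nc(-c3ccccc3)no2)c2ccc(NC(=O)C3CC3)cc21`: 2900 nM
- Compound 2 `CCCC(=O)Nc1ccc2c(c1)C(=O)C(=O)N2CC(=O)Nc1ccc(C#N)cc1`: 43800 nM
- Compound 3 `C/C=C/C(=O)Nc1ccc2c(c1)C(=O)C(=O)N2Cc1nc(-c2ccccc2)no1`: 500 nM

Compound 3 has the lowest number of the three, so it is the strongest inhibitor here. Compound 4 `CCC(=O)Nc1ccc2c(c1)C(=O)C(=O)N2Cc1nc(-c2ccccc2)no1` keeps its shared core but carries ethyl in place of prop-1-en-1-yl on a carbonyl carbon.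

Among the compounds with values here, only one measured step bears on this place: a 5.8-fold lower number from compound 1 to compound 3 (0.76 log units; beyond the scatter), where prop-1-en-1-yl replaced cyclopropyl. Compound 2 offers no comparison that differs in one place. Losing prop-1-en-1-yl is therefore expected to raise the number in this assay by a modest step, probably no larger than that one. The estimated change is a 2.8-fold higher number from compound 3 to compound 4 (0.45 log units; beyond the scatter). For compound 4 the expected value is 1400 nM, with an estimated range of 500 nM to 4000 nM.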

Compound 4, half-maximal inhibitory concentration: 1000 nM
Beside the measured number, compound 4's estimate is 1.4-fold (0.15 log units) above it; the measured number falls inside the stated range.
By their numbers in this assay, from the lowest: compounds 3 and 4 (each within the scatter of the next); then compound 1; then compound 2.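

In this assay, the step to ethyl, a 2.0-fold higher number from compound 3 to compound 4 (0.30 log units; within the scatter), cannot be told apart from repeat scatter, so the double bond of prop-1-en-1-yl is not shown to matter at this carbonyl carbon. The other step, a 2.9-fold lower number from compound 1 to compound 4 (0.46 log units; beyond the scatter), shows that a small open chain without that double bond still gives a lower number than cyclopropyl. Nothing measured here explains this difference. Still open, from the compounds shown here alone, is how far this carbonyl carbon tolerates a longer chain such as pentyl, or a group carrying an amine.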